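Octyl in place of tert-butylphenyl on a nucleoside-linked heterocycle

This account rests on a few compounds, and the source may have more. Where it says the series, first, only, none or still open, it means among the compounds named here.

Going by these compounds, the account concerns two measured compounds and one whose value is still open. Compound 1, `CC(=O)OC[C@H]1O[C@@H](n2cc(-c3cn(Cc4ccc(C(C)C)cc4)nn3)c(=O)[nH]c2=O)C[C@@H]1OC(C)=O`, and compound 2, `CC(C)(C)c1ccc(-c2cc(-c3cn([C@H]4C[C@H](O)[C@@H](CO)O4)c(=O)[nH]c3=O)on2)cc1`, were both tested in a functional assay on PC-3 cells (Homo sapiens) for cytotoxicity, read by sulforhodamine B assay, tested at 10 uM; a higher number here means more inhibition at the concentration tested (going by the name of the read-out), a lower number less inhibition. There compound 1 gives 91.3%, and compound 2 gives 87.9%. The two numbers lie within the usual scatter of one another, so compound 2 stands alongside compound 1 rather than apart from it; nothing in these two values separates them.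

Compound 3, `CCCCCCCCc1cc(-c2cn([C@H]3C[C@H](O)[C@@H](CO)O3)c(=O)[nH]c2=O)on1`, has not yet been measured in this assay. It differs from compound 2 in one place: octyl in place of 4-(tert-butyl)phenyl on an aromatic carbon. Among the compounds with values here, no step between measured compounds shows what such a change does here, so the expectation rests only on the two values at hand and on the nature of the change. A step downward of moderate size, somewhat beyond the scatter, is expected for a number 13.9 percentage points lower from compound 2 to compound 3 (beyond the scatter). On this basis compound 3 is estimated to give 74% in this assay, with a range from 45% to 92%.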

Compound 3, a percentage reported as inhibition, at one concentration (the size of the read-out at that concentration, not a potency): 77.3%
The estimate for compound 3 lay 3.3 percentage points below the measured number; the range from low to high includes it.
By their numbers in this assay, from the lowest: compound 3; then compounds 2 and 1 (each within the scatter of the next).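

The position on the aromatic carbon next to the ring nitrogen now has its first readable step: with octyl in place of 4-(tert-butyl)phenyl, this assay gives a number 10.6 percentage points lower from compound 2 to compound 3 (beyond the scatter). This shows that the position is not indifferent to the group it carries, although the step is modest. Compound 3, whose octyl has no ring, still gives 77.3% in this assay, so a six-membered aromatic ring of carbon only is not a requirement at this position for a sizeable read-out at the one concentration tested. No measurement at hand bears on what lies behind this step.

The compounds shown leave open whether a shorter or longer chain, or a chain ending in an amine or a carboxylic acid, would stand closer to compound 2 or further below compound 3. Also open, going by these compounds, is where a plain phenyl without the tert-butyl would fall, and so whether the step follows from losing the aromatic ring or from losing the branched end of the group.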